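The source may report more compounds than this note shows. Statements on the series, on what has been measured and on what is new or still open speak of the compounds shown alone.

Measured so far:
compound 1, `CC(C)(C)NCC(O)COc1ncns1`, 13.5% in a functional assay on the whole organism (artery, strain mongrel) for inhibition, with Canis familiaris (Canis lupus familiaris) as the target, with a stated time of 20 min, at a dose of 1.42 mg/kg by the intravenous route; a higher number here means a stronger effect of the compound at the dose given, a lower number a weaker effect
compound 2, `Cc1nsc(OCC(O)CNC(C)(C)C)n1`, 35.5% in this assay

Compound 2 stands highest of the two numbers, and its nearest neighbour is compound 1, which lies lower by the step of a number 22 percentage points higher from compound 1 to compound 2 (beyond the scatter). That single measured step, methyl in place of hydrogen on an aromatic carbon, is the only one on record, and it came out modest but beyond the scatter.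

Compound 3, `CC(C)(C)NCC(O)COc1nc(-c2ccccc2)ns1`, has not yet been tested in this assay. It differs from compound 2 in one place: phenyl in place of methyl on an aromatic carbon. Within the data shown here, no measured pair shows phenyl replacing methyl, so the step from compound 1 to compound 2 is the only guide, and it points weakly upward for growth at this position. For compound 3 the expectation is therefore a small rise, or no change beyond the scatter, a number 9.5 percentage points higher from compound 2 to compound 3 (within the scatter). Compound 3 is thus estimated at 45%, within the range 20% to 70%.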

Compound 3, a percentage reported as inhibition, in the whole organism at one dose (the size of the read-out at that dose, not a potency): 16.5%
Beside the measured number, compound 3's estimate is 28.5 percentage points above it, outside the stated range (below it).
By their numbers in this assay, from the lowest: compounds 1 and 3 (each within the scatter of the next); then compound 2.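

At this position, on an aromatic carbon between two ring nitrogen atoms, the effect in this assay does not climb steadily as the group grows. Phenyl in place of methyl gives a number 19 percentage points lower from compound 2 to compound 3 (beyond the scatter), while phenyl in place of hydrogen gives a number 3 percentage points higher from compound 1 to compound 3 (within the scatter), so the gain seen with methyl does not carry over to phenyl, and compound 1 and compound 3 cannot be told apart here. Among these three compounds, only the methyl compound, compound 2, stands apart from the others, and no measurement at hand explains this result.

On these data alone, it remains open how ethyl or isopropyl would behave at this position, and whether a methoxy group or an amine would match methyl. Each compound is also shown at a single dose, so these numbers speak only of a stronger or weaker effect at that dose.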